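The source may report more compounds than this note shows. Statements on the series, on what has been measured and on what is new or still open speak of the compounds shown alone.

Measured so far in a functional assay on UACC-62 cells (Homo sapiens) for inhibition, read by sulforhodamine B assay, with a stated time of 48 h, tested at 0.1 uM; a lower number here means a stronger effect, a higher number a weaker effect of the compound at the concentration tested:
- compound 1 `O=C(Nc1cccc(-n2cc(-c3ccncc3)c(-c3cc(O)cc(Cl)c3)n2)c1)Nc1ccc(Cl)c(Cl)c1` gives 99%
- compound 2 `COc1cc(Cl)cc(-c2nn(-c3cccc(NC(=O)Nc4cc(C(F)(F)F)cc(C(F)(F)F)c4)c3)cc2-c2ccncc2)c1` gives 92%

Both numbers are near the top of the read-out, so at the tested concentration neither compound shows much effect. Compound 1 and compound 2 lie within the scatter of each other; the two values do not separate them, and compound 2 differs from compound 1 in more than one place, so no single step can be read from that pair.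

Compound 3 `COc1cc(Cl)cc(-c2nn(-c3cccc(NC(=O)Nc4ccc(Cl)c(Cl)c4)c3)cc2-c2ccncc2)c1` is the next to go into this assay. It differs from compound 1 by methyl in place of hydrogen on an oxygen on an aromatic ring. Going by the values given here, no step between measured compounds isolates this change. Compound 2, which already carries the methoxy group, gives 92% in this assay, and compound 1 gives 99%, so for compound 3 no step beyond the scatter is expected; the expected step is a number 4 percentage points lower from compound 1 to compound 3 (within the scatter). For compound 3 the estimate in this assay is 95%, expected between 84% and 102%.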

Compound 3, a percentage reported as activity, at one concentration (the size of the read-out at that concentration, not a potency): 97%
For compound 3 the middle estimate is 2 percentage points below the measured one, and the stated range covers the measured number.
By their numbers in this assay, from the lowest: compounds 2, 3 and 1 (each within the scatter of the next).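

Going by these compounds alone, this is the first step that isolates one change: in this assay, hydroxy to methoxy on the aromatic ring gives a number 2 percentage points lower from compound 1 to compound 3 (within the scatter), so this pair is not separated at this position. With both values near the top of the read-out, the pair shows only that methyl on this oxygen brings no readable effect at the tested concentration, and it cannot show how the change would read for compounds with a stronger effect. No outside data at hand bear on this pair.

As far as these compounds go, whether an amine, a carboxylic acid or a longer chain such as ethoxy in place of the methoxy would separate from compound 1 stays open. Also open, from the compounds shown here alone, is how 3-chloro-5-hydroxyphenyl and 3-chloro-5-methoxyphenyl compare at other concentrations.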